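Chlorophenyl exchange on the chain carbon: cytotoxicity notes

The compounds below may be only part of what the source reports. "The series", "measured", "known", "first", "only" and "open" are said of these compounds alone.

Compound 1 (`CCC1=C(C(=O)OCC2CCCCC2)C(c2cccc(O)c2)NC(=O)N1`) gives > 10000 nM in an ADME assay on cells (Homo sapiens) for cytotoxicity, read by resazurin assay, with a stated time of 5 days (a lower number here means that less compound is tolerated, a higher number that more compound is tolerated), and this value is a limit of the assay, not a number.

Compound 2 (`COc1ccc(-c2nc(CC(=O)c3cccc(Cl)c3)nc3ccsc23)cn1`) gives 30000 nM in this assay and compound 3 (`COc1ccc(Nc2nc(CS(=O)(=O)c3cccc(Cl)c3)nc3ccsc23)cc1`) gives 60000 nM in the same read-out. Among the compounds with values here, these two numbers lie within the scatter of each other, so compound 2 stands level with compound 3, the only other number in the set.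

Compound 4 (`COc1ccc(-c2nc(CNc3cccc(Cl)c3)nc3ccsc23)cn1`) has not yet been measured. It carries (3-chlorophenyl)amino in place of (3-chlorophenyl)carbonyl on a saturated chain carbon bound to an aromatic carbon and otherwise matches compound 2.

Within the data shown here, no step between measured compounds that differ in one place is available, so the size of this change in this assay cannot be read directly from the series. Among the measured compounds shown here, the only guide is the narrow spread of the numbers, with compound 2 at 30000 nM and compound 3 at 60000 nM in the same range. The expected step (a 1.2-fold lower number from compound 2 to compound 4 (0.08 log units; within the scatter)) stays within the scatter, with no direction favoured. For compound 4 the estimated value is 25000 nM with an expected range of 10000 nM to 60000 nM in this read-out.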

Compound 4, half-maximal cytotoxic concentration: > 50000 nM
Compound 4: only a limit was reported (the forecaster's own chance of this, stated with the estimate: 25%); middle value at least 2.0-fold (0.30 log units) away from the limit.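

Compound 4 gives > 50000 nM in this assay, and this value is a limit of the assay, not a number. The series now has its first step at a single place, an at least 1.6-fold higher number from compound 2 to compound 4 (0.22 log units; that floor lies within the scatter), so exchanging (3-chlorophenyl)carbonyl for (3-chlorophenyl)amino on a saturated chain carbon bound to an aromatic carbon shows no fall in the number, and less compound is not tolerated after this change. Only a floor can be given for this step, so its true size and whether it exceeds the scatter stay unread: the limit of > 50000 nM in this assay, at which 1 of the 4 values shown sits.

The compounds shown leave open whether this position tolerates other links to the 3-chlorophenyl ring in the same way, for example (3-chlorophenyl)oxy or (3-chlorophenyl)methylamino, the latter carrying a methyl group in place of the amine hydrogen. They also leave open whether the chlorine matters at this position, since a plain phenylamino group on the same chain carbon would separate the contribution of the chlorine from that of the amino link.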